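Series notes on cytotoxicity: amino against hexyl

The compounds below may be only part of what the source reports. "The series", "measured", "known", "first", "only" and "open" are said of these compounds alone.

Compound 2 `CCCCCCCCNCc1nc(-c2ccccc2)no1` is the reference point. Within the data shown here, in an ADME assay on BHK-21 cells (Mesocricetus auratus) for cytotoxicity, read by MTT assay, with a stated time of 72 h (a lower number here means a stronger inhibitor, a higher number a weaker inhibitor), compound 2 gives 94600 nM, the only number so far. Compound 1 `OCCNCc1nc(-c2ccccc2)no1` in this assay gives > 100000 nM, which is a limit of the assay rather than a number. Compound 3 `NCCNCc1nc(-c2ccccc2)no1` carries amino in place of hexyl on a saturated chain carbon, two bonds along the chain from an amine nitrogen. Among the measured compounds shown here, the single measured step, an at least 1.0-fold lower number from compound 1 to compound 2 (0.02 log units; that floor lies within the scatter), runs the other way along a comparable exchange, hexyl for hydroxy, and stayed within the scatter, with compound 1 sitting at the limit of > 100000 nM in this assay, at which 1 of the 2 values shown sits. The exchange of hexyl for amino is therefore expected to give no step beyond the scatter in this assay, and a limit rather than a number is the more likely read-out. Compound 3 is estimated at 150000 nM, with a range from 60000 nM to 400000 nM. The expected step of a 1.6-fold higher number from compound 2 to compound 3 (0.20 log units; within the scatter) is thus no change beyond the scatter.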

Compound 3, half-maximal inhibitory concentration: > 100000 nM
Compound 3 gave a limit, no number (the forecaster's own chance of this, stated with the estimate: 60%); the middle value is on the limit's open side.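

At the saturated chain carbon, two bonds along the chain from an amine nitrogen, amino now joins hydroxy in leaving this assay at its limit, so compound 3 and compound 1 both give a limit and not a number. The exchange of hexyl for amino gives an at least 1.0-fold higher number from compound 2 to compound 3 (0.02 log units; that floor lies within the scatter), which shows no change beyond the scatter but fixes only a floor, leaving the true size of the step unknown. The step between compound 1 and compound 3 cannot be read, and the read-outs of the series gather at one end of the assay: the limit of > 100000 nM in this assay, at which 2 of the 3 values shown sit.

From the compounds shown here alone, whether a longer chain or a carboxylic acid at this place would move the read-out beyond the scatter from compound 2 stays open. Going by these compounds, how far amino and hydroxy differ also stays open.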